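A few compounds are considered here, and "the series" means these few. Any claim that something is new, unique, unknown or untested is made for them only; others in the source may bear on it.

Measured compounds and their numbers in an assay on HEK293 cells for binding affinity to 5-hydroxytryptamine receptor 7 (Homo sapiens), read by radioligand binding; a higher number here means a weaker inhibitor, a lower number a stronger inhibitor:

Compound 1, `CN1CCCN(CCn2ccc3ccc(C(F)(F)F)cc32)CC1`: 23 nM
Compound 2, `CN1CCCN(CCn2ccc3ccc(OCc4ccccc4)cc32)CC1`: 182 nM
Compound 3, `C#Cc1ccc2ccn(CCN3CCCN(C)CC3)c2c1`: 140 nM

All three share one core and differ only in the group on one aromatic carbon. Compound 3 stands second highest of the three numbers: its nearest neighbour is compound 2, with a 1.3-fold lower number from compound 2 to compound 3 (0.11 log units; within the scatter), so the two cannot be told apart, while compound 1 sits furthest away, with a 6.1-fold higher number from compound 1 to compound 3 (0.78 log units; beyond the scatter).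

Compound 4, `CCc1ccc2ccn(CCN3CCCN(C)CC3)c2c1`, has not yet been measured. It differs from compound 3 by ethyl in place of ethynyl on an aromatic carbon. For the measured compounds named here, two measured steps bear on this position: a 6.1-fold higher number from compound 1 to compound 3 (0.78 log units; beyond the scatter) and a 7.9-fold higher number from compound 1 to compound 2 (0.90 log units; beyond the scatter), both modest, and a 1.3-fold lower number from compound 2 to compound 3 (0.11 log units; within the scatter), which lies within the scatter. Going by the values given here, no measured compound carries an ethyl group, so the step to compound 4 can only be guessed from how much this position has moved so far. The expectation is a step of a 1.2-fold lower number from compound 3 to compound 4 (0.07 log units; within the scatter) in this assay, small and of uncertain direction. Compound 4 is therefore estimated at 120 nM, within a range of 45 nM to 320 nM.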

Compound 4, inhibition constant: 166 nM
Estimate against measurement, compound 4: 1.4-fold (0.14 log units) below, within the range that was stated.
By their numbers in this assay, from the lowest: compound 1; then compounds 3, 4 and 2 (each within the scatter of the next).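

Exchanging ethynyl for ethyl keeps the count of heavy atoms and removes the triple bond, yet in this assay the two compounds cannot be told apart (a 1.2-fold higher number from compound 3 to compound 4 (0.07 log units; within the scatter)), so at this position that triple bond has no readable effect on the number. Ethyl also cannot be told apart from benzyloxy (a 1.1-fold lower number from compound 2 to compound 4 (0.04 log units; within the scatter)), while trifluoromethyl remains clearly separate from ethyl (a 7.2-fold higher number from compound 1 to compound 4 (0.86 log units; beyond the scatter)), which leaves trifluoromethyl alone among the four groups shown. No measurement here explains why this group stands apart.

On these data alone, it remains open whether an amine, a carboxylic acid or a nitrile on this aromatic carbon would group with ethynyl, ethyl and benzyloxy or with trifluoromethyl. A longer chain in place of ethyl is equally untested by the compounds shown.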